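A few compounds are considered here, and "the series" means these few. Any claim that something is new, unique, unknown or untested is made for them only; others in the source may bear on it.

Values measured in a functional assay on HL-60 cells (Homo sapiens) for antiproliferative activity, with a stated time of 72 h; on this read-out lower numbers stand for stronger inhibition and higher numbers for weaker inhibition:
- Compound 1 (`OC[C@H]1O[C@@H](n2cnc3c(NCc4ccc(F)cc4)ncnc32)[C@H](O)[C@@H]1O`) gives 1200 nM
- Compound 2 (`COc1cccc(CNc2ncnc3c2ncn3[C@@H]2O[C@H](CO)[C@@H](O)[C@H]2O)c1OC`) gives > 166000 nM (a limit of the assay, not a number)
- Compound 3 (`OC[C@H]1O[C@@H](n2cnc3c(NCc4ccc(F)cc4F)ncnc32)[C@H](O)[C@@H]1O`) gives 3400 nM

Going by the values given here, of the two true numbers, compound 3 holds the higher, and its only numerical neighbour is compound 1, reached by a 2.8-fold higher number from compound 1 to compound 3 (0.45 log units; beyond the scatter). The remaining entry, for compound 2, is the limit.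

Compound 4 (`OC[C@H]1O[C@@H](n2cnc3c(NCc4ccc(F)c(F)c4F)ncnc32)[C@H](O)[C@@H]1O`) departs from compound 3 by one change: fluoro in place of hydrogen on an aromatic carbon. This is fluoro in place of hydrogen on an aromatic carbon, turning 2,4-difluorophenyl into 2,3,4-trifluorophenyl.

Among the compounds with values here, the closest precedent is the same kind of exchange, a 2.8-fold higher number from compound 1 to compound 3 (0.45 log units; beyond the scatter), a modest step. The other two steps, an at least 130-fold higher number from compound 1 to compound 2 (2.14 log units; beyond the scatter) and an at least 48-fold lower number from compound 2 to compound 3 (1.68 log units; beyond the scatter), were large, but both involve the 2,3-dimethoxyphenyl group, which compound 4 lacks, so they bear on it only weakly. With a single close precedent, a modest step towards a higher number is expected in this assay, with wide margins. The estimate amounts to a 2.1-fold higher number from compound 3 to compound 4 (0.31 log units; beyond the scatter) as the expected change. For compound 4 the estimated value is 7000 nM, with an expected range from 2000 nM to 25000 nM.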

Compound 4, half-maximal inhibitory concentration: 13000 nM
For compound 4 the middle estimate is 1.9-fold (0.27 log units) below the measured one; the range from low to high includes it.
By their numbers in this assay, from the lowest: compound 1; then compound 3; then compound 4. At a limit, above all of these: compound 2.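

In this assay, fluoro in place of hydrogen at the position ortho to two fluoro groups gives a 3.8-fold higher number from compound 3 to compound 4 (0.58 log units; beyond the scatter), a modest step in the same direction as the earlier exchange, a 2.8-fold higher number from compound 1 to compound 3 (0.45 log units; beyond the scatter). The two exchanges now reach a large overall step from 4-fluorophenyl to 2,3,4-trifluorophenyl, an 11-fold higher number from compound 1 to compound 4 (1.03 log units; beyond the scatter), so across these three compounds each added fluoro goes with weaker inhibition, and none of them goes against this; even so, the 2,3,4-trifluorophenyl group remains far from the 2,3-dimethoxyphenyl group, an at least 12-fold lower number from compound 2 to compound 4 (1.10 log units; beyond the scatter). The entry for compound 2 is a limit, not a number: the limit of > 166000 nM in this assay, at which 1 of the 4 values shown sits.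

The compounds shown leave open whether the rise belongs to fluoro itself or to any group at this position, a question that chloro, methyl or hydroxy there would address. They also leave open how a 3-fluorophenyl group on its own, or a longer chain between the aromatic ring and the nitrogen, would read in this assay.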